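This account rests on a few compounds, and the source may have more. Where it says the series, first, only, none or still open, it means among the compounds named here.

Measured so far in a functional assay on DLD-1 cells (Homo sapiens) for antiproliferative activity, read by CellTiter-Glo, with a stated time of 72 h; on this read-out lower numbers stand for stronger inhibition and higher numbers for weaker inhibition:
compound 1, `CC1CCN(C2CCN(S(=O)(=O)c3ccccc3Br)CC2)CC1`, gives 3 nM
compound 2, `CC1CCN(C2CCN(S(=O)(=O)c3ccccc3-c3ccc(C(F)(F)F)cc3)CC2)CC1`, gives 122 nM
compound 3, `CC1CCN(C2CCN(S(=O)(=O)c3ccccc3-c3ccccc3)CC2)CC1`, gives 0.96 nM

Compound 1 stands second highest of the three numbers: compound 3 lies below it, a 3.1-fold lower number from compound 1 to compound 3 (0.49 log units; beyond the scatter), and compound 2 above it, a 41-fold higher number from compound 1 to compound 2 (1.61 log units; beyond the scatter). Compound 4, `CC1CCN(C2CCN(S(=O)(=O)c3cn(C)cn3)CC2)CC1`, differs from compound 1 as follows: 1-methyl-1H-imidazol-4-yl in place of 2-bromophenyl on a sulfonyl sulfur. Among the measured compounds shown here, no measured step exchanges the whole group on the sulfonyl sulfur; the steps so far only alter what sits on the aromatic ring, and they span modest to large, the widest being a 130-fold lower number from compound 2 to compound 3 (2.10 log units; beyond the scatter). This spread argues for a wide range rather than a firm direction. A higher number is expected for compound 4, a 10-fold higher number from compound 1 to compound 4 (1.00 log units; beyond the scatter). Compound 4 is estimated at 30 nM, within 3 nM to 300 nM.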

Compound 4, half-maximal inhibitory concentration: > 5000 nM
Compound 4 ended at the assay's limit; the forecaster's own chance of this, stated with the estimate: 5%; middle value at least 160-fold (2.22 log units) from the limit.
By their numbers in this assay, from the lowest: compound 3; then compound 1; then compound 2. At a limit, above all of these: compound 4.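

Exchanging the whole group on the sulfonyl sulfur, rather than only what sits on the aromatic ring, gives an at least 1600-fold higher number from compound 1 to compound 4 (3.22 log units; beyond the scatter) in this assay, wider than any earlier step. In the one case shown, a five-membered aromatic ring with 2 hetero atoms does not stand in for the 2-bromophenyl group. Compound 4 stands at a limit, so the true size of this step stays unknown: the limit of > 5000 nM in this assay, at which 1 of the 4 values shown sits.

Compound 4 changes ring size, ring nitrogens and the bromine at once, and the compounds shown do not separate these. Open too, on these data alone, is how a plain phenyl or a pyridine on the sulfonyl sulfur would read.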